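The source may hold more compounds than are shown below. What is called first, only, known or untested is meant among the compounds shown, and "the series" means these compounds.

Of the compounds shown here, three built on one shared core have been tested in an ADME assay on MT4 cells (Homo sapiens) for cytotoxicity, read by MTT assay, with a stated time of 4 days; on this read-out lower numbers stand for higher toxicity in this test and higher numbers for lower toxicity in this test. Compound 1 `CCOC(=O)c1cnc(N2CCN(Cc3ccc(C(F)(F)F)cc3)CC2)nc1Oc1c(C)cc(-c2ccc(C#N)cc2)cc1C` gives only a limit in this assay, > 125000 nM. Compound 2 `CCOC(=O)c1cnc(N2CCN(Cc3ccc(F)cc3)CC2)nc1Oc1c(C)cc(-c2ccc(C#N)cc2)cc1C` likewise reaches only a limit in this assay, > 117000 nM. Compound 3 `CCOC(=O)c1cnc(N2CCN(Cc3ccccc3Br)CC2)nc1Oc1c(C)cc(-c2ccc(C#N)cc2)cc1C` also stands at a limit in this assay, > 125000 nM. With every value a limit rather than a number, none of the steps between these compounds can be sized: a step that the two limits leave unreadable from compound 1 to compound 2, a step that the two limits leave unreadable from compound 1 to compound 3 and a step that the two limits leave unreadable from compound 2 to compound 3. Two anchors sum this up: the limit of > 117000 nM in this assay, at which 1 of the 3 values shown sits, and (the limit of > 125000 nM in this assay, at which 2 of the 3 values shown sit).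

Compound 4 `CCOC(=O)c1ccc(CN2CCN(c3ncc(C(=O)OCC)c(Oc4c(C)cc(-c5ccc(C#N)cc5)cc4C)n3)CC2)cc1` differs from compound 3 by 4-(ethoxycarbonyl)phenyl in place of 2-bromophenyl on a saturated chain carbon bound to an amine nitrogen in a ring. Among the measured compounds shown here, no measured step offers a readable size, so the expectation rests only on compound 3 sitting at its limit, > 125000 nM. The change is expected to give a step that the limit leaves unreadable from compound 3 to compound 4, within the scatter. Compound 4 is therefore expected to show about 150000 nM, with a range from 60000 nM to 400000 nM, and most likely this assay will again report only a limit.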

Compound 4, half-maximal cytotoxic concentration: > 125000 nM
Compound 4: no number, only a limit; the forecaster's own chance of this, stated with the estimate: 85%; the middle value does not contradict the limit.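

Compound 4 again gives only a limit in this assay, > 125000 nM, so its steps from compound 1, compound 2 and compound 3 cannot be read. The compounds shown leave open at what concentration any of the four harms these cells, and whether these group changes alter that concentration at all.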